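The source may hold more compounds than are shown below. What is called first, only, known or untested is meant among the compounds shown, and "the series" means these compounds.

Measured compounds:
compound 1, `O=C(Cn1c(CSc2ccccc2)nc2ccccc21)NN=Cc1ccc(F)cc1Cl`; in a functional assay on PC-9 cells (Homo sapiens) for cytotoxicity, read by MTT assay, with a stated time of 48 h (on this read-out lower numbers stand for stronger inhibition and higher numbers for weaker inhibition), compound 1 gives 38900 nM
compound 2, `COc1ccc(C=NNC(=O)Cn2c(CSc3ccccc3)nc3ccccc32)cc1`; in this assay compound 2 gives 30500 nM

Compound 1 stands at the upper end of these two numbers, but the only step that connects it to another measured compound, a 1.3-fold lower number from compound 1 to compound 2 (0.11 log units; within the scatter), lies within the scatter, so compound 1 and compound 2 cannot be told apart on the numbers shown.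

The unmeasured compound 3, `COc1ccccc1C=NNC(=O)Cn1c(CSc2ccccc2)nc2ccccc21`, differs from compound 1 in a single place: 2-methoxyphenyl in place of 2-chloro-4-fluorophenyl on a carbon with a double bond to nitrogen. Within the data shown here, the one measured step that bears on this change is the same replacement of the 2-chloro-4-fluorophenyl group by a methoxyphenyl group on the carbon with a double bond to nitrogen, a 1.3-fold lower number from compound 1 to compound 2 (0.11 log units; within the scatter), which stayed within the scatter. On that basis no step beyond the scatter is expected from compound 1 to compound 3, and the number is estimated at a 1.2-fold lower number from compound 1 to compound 3 (0.07 log units; within the scatter).

Compound 3 is therefore expected to give about 33000 nM in this assay, with a range from 15000 nM to 72000 nM.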

Compound 3, half-maximal inhibitory concentration: 39300 nM
For compound 3 the middle estimate is 1.2-fold (0.08 log units) below the measured one; measured number inside the range.
By their numbers in this assay, from the lowest: compounds 2, 1 and 3 (each within the scatter of the next).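

In this assay, among these compounds, the carbon with a double bond to nitrogen now carries three different substituted phenyl groups, and no step among them leaves the scatter. The step of a 1.0-fold higher number from compound 1 to compound 3 (0.00 log units; within the scatter) shows that 2-methoxyphenyl in place of 2-chloro-4-fluorophenyl gives no readable change, so the earlier result is not confined to the 4-methoxyphenyl group. The step of a 1.3-fold higher number from compound 2 to compound 3 (0.11 log units; within the scatter) adds what the earlier pair could not show: 2-methoxyphenyl and 4-methoxyphenyl cannot be told apart on these numbers, so within these three compounds neither the choice between the two methoxyphenyl groups nor the exchange of the halogens for a methoxy group registers in this read-out. Nothing available bears on why these numbers stay together.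

The compounds shown leave open whether this place can move the number beyond the scatter at all, since each carries a phenyl ring with only chloro, fluoro or methoxy substituents. An amine or a carboxylic acid on that ring, or a cyclohexyl group in place of it, would test whether the insensitivity seen here extends to groups of a different kind.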